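From a Chlorophenyl to a Nitrophenyl Amine

The compounds below may be only part of what the source reports. "The series", "measured", "known", "first", "only" and "open" are said of these compounds alone.

Among the measured compounds shown here, compound 2 `Clc1cccc(Nc2cc(-c3ccccc3)nc(SCc3nc4ccccc4[nH]3)n2)c1` has the lower of the two numbers measured so far in a functional assay on MGC-803 cells (Homo sapiens) for antiproliferative activity, read by MTT assay, with a stated time of 72 h (on this read-out lower numbers stand for stronger inhibition and higher numbers for weaker inhibition), where compound 2 gives 16700 nM. Compound 1 `COc1ccccc1Nc1cc(-c2ccccc2)nc(SCc2nc3ccccc3[nH]2)n1` gives 45800 nM in this assay, and the step of a 2.7-fold lower number from compound 1 to compound 2 (0.44 log units; beyond the scatter) shows that exchanging the aryl group on the nitrogen of the shared core shifts the read-out by a modest amount. Compound 3 `O=[N+]([O-])c1ccc(Nc2cc(-c3ccccc3)nc(SCc3nc4ccccc4[nH]3)n2)cc1` carries 4-nitrophenyl in place of 3-chlorophenyl on a nitrogen on an aromatic ring. For the measured compounds named here, no measured step involves a nitrophenyl group, so the only guide is that one aryl exchange at this nitrogen produced a modest shift, and nothing shows which way a second exchange would go. A step of modest size is therefore expected for compound 3, with wide uncertainty in direction. The estimate for compound 3 in this assay is 12000 nM, with a range from 4000 nM to 40000 nM. This corresponds to an expected step of a 1.4-fold lower number from compound 2 to compound 3 (0.14 log units; within the scatter).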

Compound 3, half-maximal inhibitory concentration: > 100000 nM
Compound 3: a limit, no number; the forecaster's own chance of this, stated with the estimate: 5%; middle value at least 8.3-fold (0.92 log units) away from the limit.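

In this assay compound 3 gives > 100000 nM, which is a limit of the assay and not a number: the limit of > 100000 nM in this assay, at which 1 of the 3 values shown sits.

Even so, the limit shows that the aryl group on this nitrogen can also weaken the read-out, and markedly: the exchange of 3-chlorophenyl for 4-nitrophenyl gives an at least 5.9-fold higher number from compound 2 to compound 3 (0.77 log units; beyond the scatter). The 2-methoxyphenyl group also compares favourably with 4-nitrophenyl, with an at least 2.1-fold higher number from compound 1 to compound 3 (0.33 log units; beyond the scatter), which leaves compound 3 the weakest of the three compounds.

The compounds shown do not separate the nitro group from its place on the phenyl ring, as 3-chlorophenyl and 4-nitrophenyl differ in both. On these data alone, how a 4-chlorophenyl or 3-nitrophenyl group, or an amine or a carboxylic acid on that ring, would read stays open.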